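A few compounds are considered here, and "the series" means these few. Any claim that something is new, unique, unknown or untested is made for them only; others in the source may bear on it.

In a functional assay on SMMC-7721 cells (Homo sapiens) for inhibition, read by CCK-8 assay, with a stated time of 72 h, tested at 2 uM (a higher number here means more inhibition of growth at the concentration tested, a lower number less inhibition of growth), compound 3 `CCc1ccc(SCc2ccc(C(=O)Nc3ccccc3N)cc2)cc1` gives 25.7% and stands highest of the three compounds measured. On this scale compound 1 `Cc1cc(C)cc(SCc2ccc(/C=C/C(=O)Nc3ccccc3N)cc2)c1` gives 8.61% and compound 2 `Nc1ccccc1NC(=O)/C=C/c1ccc(CSc2cccc(F)c2)cc1` gives 8.56%. Compound 3 lies beyond the scatter from both of them. Compound 4 `Nc1ccccc1NC(=O)c1ccc(CSc2ccc(Br)cc2)cc1` changes one group of compound 3, with bromo in place of ethyl on an aromatic carbon. Among the measured compounds shown here, the only measured step that swaps groups on such a ring is a number 0.1 percentage points lower from compound 1 to compound 2 (within the scatter) and it stays within the scatter. Compounds 1 and 2 also differ from compound 3 elsewhere, so this guide is loose. The expected change, a number 2.7 percentage points lower from compound 3 to compound 4 (within the scatter) in this assay, is small and within the scatter. Compound 4 is estimated at 23% with an expected range of 10% to 38% here.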

Compound 4, percent growth inhibition at one concentration: 10%
Compound 4: the middle estimate sits 13 percentage points above what was measured; measured number inside the range.
By their numbers in this assay, from the lowest: compounds 2, 1 and 4 (each within the scatter of the next); then compound 3.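

Going from 4-ethylphenyl to 4-bromophenyl gives a number 15.7 percentage points lower from compound 3 to compound 4 (beyond the scatter) in this assay. This shows that a single group swap at this ring position, para to a large group, can shift growth inhibition beyond the scatter, which the ring change from compound 1 to compound 2 did not show. No measurement given here explains this step. One swap cannot show how far the outcome depends on the group at this position. Going by these compounds, how a propyl chain, an amine or a carboxylic acid would behave here remains open.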